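A Bulkier Sulfonamide Substituent in a Urea Series

A few compounds are considered here, and "the series" means these few. Any claim that something is new, unique, unknown or untested is made for them only; others in the source may bear on it.

Measured so far, in an assay on isolated protein for activation of Nicotinamide phosphoribosyltransferase (Homo sapiens); a lower number here means that less compound is needed, a higher number that more compound is needed for the effect:
- compound 1, `CCOC(=O)c1ccc(N(C)C(=O)NCc2ccncc2)cc1`, a limit of > 100000 nM
- compound 2, `CNS(=O)(=O)c1ccc(NC(=O)NCc2ccncc2)cc1`, 3230 nM
- compound 3, `CCOC(=O)c1ccc(NC(=O)NCc2cc[nH]n2)cc1`, 69000 nM

The value of compound 1 is a limit of the assay, not a number (the limit of > 100000 nM in this assay, at which 1 of the 3 values shown sits). Among the two numbers given, compound 2 stands lowest, and compound 3 sits far enough above it to lie beyond the scatter.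

Compound 4, `CCN(C1CCCC1)S(=O)(=O)c1ccc(NC(=O)NCc2ccncc2)cc1`, differs from compound 2 in one place: cyclopentyl(ethyl)amino in place of methylamino on a sulfonyl sulfur. For the measured compounds named here, no measured pair shows a comparable change, so there is no direct guide. A modest gain is expected, the step from compound 2 to compound 4 estimated at a 2.2-fold lower number from compound 2 to compound 4 (0.33 log units; beyond the scatter). Compound 4 is thus expected to give about 1500 nM, within a range from 300 nM to 8000 nM.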

Compound 4, half-maximal effective concentration: 60 nM
Estimate against measurement, compound 4: 25-fold (1.40 log units) above; measured number below the stated range.
By their numbers in this assay, from the lowest: compound 4; then compound 2; then compound 3. At a limit, above all of these: compound 1.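

Replacing methylamino with cyclopentyl(ethyl)amino on the sulfonyl sulfur gives a 54-fold lower number from compound 2 to compound 4 (1.73 log units; beyond the scatter) in this assay, so a much larger group is accepted at this position and the number falls sharply. The earlier compounds shown here held no change at this place, and this step also removes the hydrogen-bond donor of methylamino while adding a five-membered ring of carbon only. Nothing measured here accounts for the size of this step.

Going by these compounds, it remains open whether ethylamino or cyclopentylamino alone would give the same gain. A piperidine ring or a dimethylamino group on the sulfonyl sulfur would help separate the contribution of size from that of the lost donor.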